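Urea series: amino in place of fluoro, cytotoxicity note

This account rests on a few compounds, and the source may have more. Where it says the series, first, only, none or still open, it means among the compounds named here.

compound 1, `Cc1cc(NC(=O)Nc2ccc(F)cc2)c2ccccc2n1`: > 25000 nM
compound 2, `Cc1cc(NC(=O)Nc2ccc(F)cc2F)c2ccccc2n1`: > 25000 nM
compound 3, `Cc1cc(NC(=O)Nc2ccc(N)cc2)c2ccccc2n1`: not yet measured

In an ADME assay on Raji cells (Homo sapiens) for cytotoxicity, with a stated time of 72 h (on this read-out lower numbers stand for an effect already at smaller amounts and higher numbers for an effect only at larger amounts of compound), compound 1 gives > 25000 nM, which is a limit of the assay and not a number. Compound 2 gives > 25000 nM in this assay, again a limit. The step that the two limits leave unreadable from compound 1 to compound 2 is therefore of unreadable size. Compound 1 thus stands at the limit of > 25000 nM in this assay, at which 2 of the 2 values shown sit, and has no number of its own in this assay.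

Compound 3 differs from compound 1 by amino in place of fluoro on an aromatic carbon. For the measured compounds named here, the only measured step, a step that the two limits leave unreadable from compound 1 to compound 2, concerns a different change and is unreadable, so nothing measured bears on amino in place of fluoro. With both shown values sitting at the limit, no shift in either direction beyond the scatter is expected in this assay. The step that the limit leaves unreadable from compound 1 to compound 3 is accordingly expected to be small. Compound 3 is estimated at 30000 nM, within 8000 nM to 100000 nM, and most likely reported as a limit once more.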

Compound 3, half-maximal effective concentration: > 25000 nM
Compound 3: no number, only a limit; the forecaster's own chance of this, stated with the estimate: 80%; the middle value lies beyond the limit too.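

Compound 3 gives > 25000 nM in this assay, a limit and not a number, so no step can be read between compound 3 and compound 1 or compound 2. The compounds shown leave open whether amino in place of fluoro changes cytotoxicity, and how compound 1, compound 2 and compound 3 rank: the limit of > 25000 nM in this assay, at which 3 of the 3 values shown sit.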